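The source may hold more compounds than are shown below. What is called first, only, known or untested is meant among the compounds shown, and "the series" means these compounds.

Going by the values given here, in a functional assay on HepG2 cells (Homo sapiens) for antiproliferative activity, read by MTT assay, with a stated time of 24 h (a lower number here means a stronger inhibitor, a higher number a weaker inhibitor), compound 1 `COC(=O)c1scc(-c2ccc(NC(=O)c3cccc(I)c3)cc2)c1OC` gives 16500 nM and holds the higher of the two numbers measured so far, while compound 2 `COC(=O)c1scc(-c2ccc(NC(=O)c3cccc(OC(F)(F)F)c3)cc2)c1OC` gives 720 nM in the same test. Compound 3 `COC(=O)c1scc(-c2ccc(NC(=O)c3ccc(C(F)(F)F)cc3)cc2)c1OC` has 4-(trifluoromethyl)phenyl in place of 3-iodophenyl on a carbonyl carbon. Among the compounds with values here, only one measured step bears on this change: trifluoromethoxy in place of iodo gave a 23-fold lower number from compound 1 to compound 2 (1.36 log units; beyond the scatter) as its result. The group entering compound 3 is a different one, so a somewhat smaller step towards a lower number is expected. Compound 3 is estimated at 2500 nM within a range of 600 nM to 10000 nM as its likely span. That would be an expected 6.6-fold lower number from compound 1 to compound 3 (0.82 log units; beyond the scatter) overall.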

Compound 3, half-maximal inhibitory concentration: 24600 nM
Estimate against measurement, compound 3: 9.8-fold (0.99 log units) below; measured number outside the range, above it.
By their numbers in this assay, from the lowest: compound 2; then compounds 1 and 3 (each within the scatter of the next).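

In this assay, replacing 3-iodophenyl with 4-(trifluoromethyl)phenyl on the carbonyl carbon gives a 1.5-fold higher number from compound 1 to compound 3 (0.17 log units; within the scatter), so this change makes no clear difference. The large step for trifluoromethoxy in place of iodo, a 23-fold lower number from compound 1 to compound 2 (1.36 log units; beyond the scatter), therefore does not carry over to this change. Nothing available explains this contrast. The compounds shown leave open whether the group or its place on the ring matters more, since compound 3 changes both at once. Going by these compounds, how a phenyl ring carrying an amine or a carboxylic acid would behave on this carbonyl carbon also remains open.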